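Piperidinylpropyl Replaces the Triazolyl Side Chain on the Core

The source may report more compounds than this note shows. Statements on the series, on what has been measured and on what is new or still open speak of the compounds shown alone.

Measured compounds:
compound 1, `CN1CCN(CCCCCCn2c3c(c4ccccc42)C(=O)c2c[n+]([O-])c4ccccc4c2C3=O)CC1`: 2900 nM
compound 2, `O=C1c2c[n+]([O-])c3ccccc3c2C(=O)c2c1c1ccccc1n2Cc1cn(CC(O)CO)nn1`: 250 nM

Of the compounds shown here, two sharing the same core have been tested in a functional assay on HCT-116 cells (Homo sapiens) for cytotoxicity, read by MTT assay, with a stated time of 72 h; a higher number here means a weaker inhibitor, a lower number a stronger inhibitor. Compound 1 gives 2900 nM, and compound 2 gives 250 nM, the lowest of the two numbers; the nearest is compound 1, reached by a 12-fold lower number from compound 1 to compound 2 (1.06 log units; beyond the scatter).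

Compound 3, `O=C1c2c[n+]([O-])c3ccccc3c2C(=O)c2c1c1ccccc1n2CCCCN1CCCCC1`, has not yet been measured in this assay. It differs from compound 2 in one place: 3-(piperidin-1-yl)propyl in place of 1-(2,3-dihydroxypropyl)-1H-1,2,3-triazol-4-yl on a saturated chain carbon bound to an aromatic nitrogen. Going by the values given here, the only measured step that bears on this is a 12-fold lower number from compound 1 to compound 2 (1.06 log units; beyond the scatter), where a saturated chain ending in a ring amine was exchanged for the triazolyl group. Compound 3 reverses that kind of exchange, so compound 3 is expected to give a higher number than compound 2, estimated as a 6.0-fold higher number from compound 2 to compound 3 (0.78 log units; beyond the scatter), though the chain and ring are not those of compound 1. Compound 3 is therefore estimated at 1500 nM, in the range 500 nM to 5000 nM.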

Compound 3, half-maximal inhibitory concentration: 200 nM
Estimate against measurement, compound 3: 7.5-fold (0.88 log units) above; the whole stated range lies above it.
By their numbers in this assay, from the lowest: compounds 3 and 2 (each within the scatter of the next); then compound 1.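

In this assay, exchanging the triazolyl group for 3-(piperidin-1-yl)propyl on a saturated chain carbon bound to an aromatic nitrogen gives a 1.3-fold lower number from compound 2 to compound 3 (0.10 log units; within the scatter), so a saturated chain ending in a ring amine does not by itself go with the higher number of compound 1. The two ring-amine chains are instead separated by a 15-fold lower number from compound 1 to compound 3 (1.16 log units; beyond the scatter), with piperidin-1-yl in place of 2-(4-methylpiperazin-1-yl)ethyl on a saturated chain carbon, four bonds along the chain from an aromatic nitrogen. No measurement here accounts for either step.

Compound 1 and compound 3 differ in chain length and terminal ring together, and the compounds shown do not separate the two. Open too, as far as these compounds go, is how a 4-(4-methylpiperazin-1-yl)butyl chain or a morpholine-terminated chain on the shared core would read.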